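The source may report more compounds than this note shows. Statements on the series, on what has been measured and on what is new or still open speak of the compounds shown alone.

Measured compounds:
Compound 1, `N#Cc1cccc(COc2ccc(-c3cc(CN4CCN(Cc5ccc(C(F)(F)F)cc5)CC4)no3)cc2)c1`: 100 nM
Compound 2, `N#Cc1cccc(COc2ccc(-c3cc(CNC4CCN(Cc5ccccc5)CC4)no3)cc2)c1`: 2500 nM
Compound 3, `N#Cc1cccc(COc2ccc(-c3cc(CN4CCN(Cc5ccc(C(F)(F)F)cc5)CC4)no3)cc2F)c1`: 90 nM

All three were tested in a functional assay on Huh-7 cells (Homo sapiens) for antiproliferative activity, read by sulforhodamine B assay, with a stated time of 72 h; on this read-out lower numbers stand for stronger inhibition and higher numbers for weaker inhibition. In this assay compound 1 gives 100 nM, and in the same assay compound 3 gives 90 nM. Compound 1 and compound 3 differ in a single place, and this change is fluoro in place of hydrogen on an aromatic carbon. The measured step is a 1.1-fold lower number from compound 1 to compound 3 (0.05 log units; within the scatter), so the two numbers are, for practical purposes, the same.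

Compound 2, which in this assay gives 2500 nM, differs from compound 1 in more than one place; the difference between the two cores is not broken down here. Its number is the highest of the three, and its distance from both compound 1 and compound 3 lies beyond the scatter, so it is the weakest inhibitor among the measured compounds.

Compound 4, `N#Cc1cccc(COc2ccc(-c3cc(CNC4CCN(Cc5ccccc5)CC4)no3)cc2F)c1`, has not yet been measured. It stands to compound 2 exactly as compound 3 stands to compound 1: the change is fluoro in place of hydrogen on an aromatic carbon, the same change seen in the measured pair. The step from compound 2 to compound 4 is expected to be a 1.1-fold lower number from compound 2 to compound 4 (0.04 log units; within the scatter), an expectation that rests on compound 1 and compound 3, because a 1.1-fold lower number from compound 1 to compound 3 (0.05 log units; within the scatter) showed that this change hardly moved the number there. Compound 4 is therefore estimated at 2300 nM in this assay, most likely somewhere between 1000 nM and 5500 nM.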

Compound 4, half-maximal inhibitory concentration: 2300 nM
Compound 4: the middle estimate sits on the measured number at the digits printed; the range from low to high includes it.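

In this assay, the new step is a 1.1-fold lower number from compound 2 to compound 4 (0.04 log units; within the scatter), so with fluoro in place of hydrogen on an aromatic carbon, the two numbers on this core count as the same. The same swap on the other core gives a closely matching result, and the two steps do not differ: the same change on two cores in this assay, a 1.1-fold lower number (0.05 log units; within the scatter) from compound 1 to compound 3 and a 1.1-fold lower number (0.04 log units; within the scatter) from compound 2 to compound 4, 1.0-fold (0.01 log units) apart, within the scatter of two such steps. This shows that, across these two pairs, the swap can be carried from one core to the other with the same outcome, namely no shift in the number beyond the usual scatter, but it does not show that this would hold on any further core, in any other assay, or for a change that really does move the number, since neither step here is larger than the scatter.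

Going by these compounds, what remains open is whether a different group on the same aromatic carbon, ortho to the (3-cyanobenzyl)oxy group, such as chloro, methoxy or an amine, would leave the number just as undisturbed on both cores. The compounds shown also leave open whether fluoro on another carbon of that ring would behave in the same way, as each of the two pairs tests only this one place.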